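Cytotoxicity outlook on removing one methyl from compound 1

The compounds below may be only part of what the source reports. "The series", "measured", "known", "first", "only" and "open" are said of these compounds alone.

In a toxicity assay on MT4 cells (Homo sapiens) for cytotoxicity, read by MTT assay (on this read-out lower numbers stand for higher toxicity in this test and higher numbers for lower toxicity in this test), compound 1 (`Cc1cc(-c2ccccc2F)cc(C)c1Oc1cc(N)nc(Nc2ccc(C#N)cc2)n1`) gives 29300 nM, compound 2 (`Cc1cc(-c2cccc(Cl)c2)cc(C)c1Oc1cc(N)nc(Nc2ccc(C#N)cc2)n1`) gives 22300 nM and compound 3 (`COc1cccc(-c2cc(C)c(Oc3cc(N)nc(Nc4ccc(C#N)cc4)n3)c(C)c2)c1`) gives 19300 nM. These three values lie within the scatter of one another, so compound 1 holds no distinct place among them. Compound 4 (`Cc1cc(-c2ccccc2F)ccc1Oc1cc(N)nc(Nc2ccc(C#N)cc2)n1`) differs from compound 1 as follows: hydrogen in place of methyl on an aromatic carbon. The measured steps, a 1.3-fold lower number from compound 1 to compound 2 (0.12 log units; within the scatter), a 1.5-fold lower number from compound 1 to compound 3 (0.18 log units; within the scatter) and a 1.2-fold lower number from compound 2 to compound 3 (0.06 log units; within the scatter), all stay within the scatter, but they vary only the substituted phenyl group and leave this methyl untouched. No step beyond the scatter is therefore expected in this assay, in either direction. The expected step is a 1.2-fold lower number from compound 1 to compound 4 (0.07 log units; within the scatter). For compound 4 the estimated value is 25000 nM, with an expected range of 10000 nM to 65000 nM.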

Compound 4, half-maximal cytotoxic concentration: 29500 nM
For compound 4 the middle estimate is 1.2-fold (0.07 log units) below the measured one; the range from low to high includes it.
By their numbers in this assay, from the lowest: compounds 3, 2, 1 and 4 (each within the scatter of the next).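

In this assay, hydrogen in place of methyl gives a 1.0-fold higher number from compound 1 to compound 4 (0.00 log units; within the scatter), the first step shown at this position rather than on the substituted phenyl group. On this aromatic carbon, ortho to a large group, the read-out therefore does not depend on the methyl while the remaining methyl stays in place. Nothing available bears on the reason for this. Still open, from the compounds shown here alone, is whether a larger group at this carbon, such as an ethyl group or an amine, would also stay within the scatter. Also open, going by these compounds, is what replacing the remaining methyl with hydrogen would do.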